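Indole hydrazones on pancreatic carcinoma cells: removing the methoxy

The compounds below may be only part of what the source reports. "The series", "measured", "known", "first", "only" and "open" are said of these compounds alone.

Measured values in a functional assay on MIA PaCa-2 cells (Homo sapiens) for cytotoxicity; a higher number here means a weaker inhibitor, a lower number a stronger inhibitor:
Compound 1 `COc1ccc(Cn2cc(/C=N\NC(=O)c3c[nH]c4ccccc34)c3cc(OC)ccc32)cc1`: 30500 nM
Compound 2 `COc1ccc2c(c1)c(/C=N\NC(=O)c1cn(C)c3ccccc13)cn2Cc1ccc(Cl)cc1`: 56400 nM
Compound 3 `COc1ccc2c(c1)c(/C=N\NC(=O)c1c[nH]c3ccccc13)cn2Cc1ccc(Cl)cc1`: 26700 nM

Compound 3 carries the lowest of the three numbers, yet the step of a 1.1-fold lower number from compound 1 to compound 3 (0.06 log units; within the scatter) lies within the scatter, so compound 1 and compound 3 cannot be told apart; only compound 2 stands apart, through a 2.1-fold lower number from compound 2 to compound 3 (0.32 log units; beyond the scatter).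

Compound 4 `O=C(N/N=C\c1cn(Cc2ccc(Cl)cc2)c2ccccc12)c1c[nH]c2ccccc12` differs from compound 3 by hydrogen in place of methoxy on an aromatic carbon. Neither measured step touches this position: a 1.1-fold lower number from compound 1 to compound 3 (0.06 log units; within the scatter) concerns the benzyl substituent and a 2.1-fold lower number from compound 2 to compound 3 (0.32 log units; beyond the scatter) the indole nitrogen. No guidance on the methoxy itself exists, so in this assay no step beyond the scatter is expected, a 1.1-fold higher number from compound 3 to compound 4 (0.05 log units; within the scatter). Compound 4 is therefore estimated at 30000 nM in this assay, with a range from 10000 nM to 90000 nM.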

Compound 4, half-maximal inhibitory concentration: 44300 nM
Estimate against measurement, compound 4: 1.5-fold (0.17 log units) below; the range from low to high includes it.
By their numbers in this assay, from the lowest: compounds 3, 1, 4 and 2 (each within the scatter of the next, the first and the last beyond it).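

Hydrogen in place of methoxy on this aromatic carbon gives the first step read at this position: in this assay it is a 1.7-fold higher number from compound 3 to compound 4 (0.22 log units; within the scatter). The methoxy is therefore not required to keep the number within the scatter of that of compound 3, and compound 3 and compound 4 cannot be told apart. Nothing available explains the size of this step.

Open, from the compounds shown here alone, is whether an amine, a carboxylic acid or a longer alkoxy chain on this carbon would move the number beyond the scatter. Also open, going by these compounds, is whether the hydrogen reads the same alongside a methyl on the indole nitrogen.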